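Aryl Variation at the Pyrazole Carbon: Compound 3 Outlook

The source may hold more compounds than are shown below. What is called first, only, known or untested is meant among the compounds shown, and "the series" means these compounds.

Measured so far:
Compound 1 `Cc1ccccc1-c1c(C)nn(-c2nc(-c3ccc(Cl)c(Cl)c3)c(SC(C)C)s2)c1C(=O)O` — 5500 nM
Compound 2 `Cc1cc(C)cc(-c2c(C)nn(-c3nc(-c4ccc(Cl)c(Cl)c4)c(SC(C)C)s3)c2C(=O)O)c1` — 2700 nM

Both numbers come from a functional assay on BJAB cells (Homo sapiens) for antiproliferative activity, with a stated time of 4 days; on this read-out higher numbers stand for an effect only at larger amounts of compound and lower numbers for an effect already at smaller amounts. For the measured compounds named here, compound 2 holds the lowest of the two numbers, with compound 1 as its only neighbour, and the one step on record, a 2.0-fold lower number from compound 1 to compound 2 (0.31 log units; beyond the scatter), is modest but beyond the scatter.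

Compound 3 `Cc1nn(-c2nc(-c3ccc(Cl)c(Cl)c3)c(SC(C)C)s2)c(C(=O)O)c1-c1cccc(C(F)(F)F)c1` differs from compound 2 in one place: 3-(trifluoromethyl)phenyl in place of 3,5-dimethylphenyl on an aromatic carbon. Going by the values given here, the only step that bears on this change is the one from compound 1 to compound 2, where swapping one aryl group on the same aromatic carbon for another shifted this assay by a modest amount. That step concerned different aryl groups, so it gives direction for the size of an aryl swap but not for this particular pair. With no other aryl variation recorded, the expectation is a step of similar or smaller size, most likely within the scatter, in either direction, so a 1.1-fold higher number from compound 2 to compound 3 (0.05 log units; within the scatter) is the estimated outcome. On that basis compound 3 is expected to give 3000 nM in this assay, with a range of 1200 nM to 7500 nM.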

Compound 3, half-maximal effective concentration: 22000 nM
Compound 3: the middle estimate sits 7.3-fold (0.87 log units) below what was measured, and the stated range ends below it.
By their numbers in this assay, from the lowest: compound 2; then compound 1; then compound 3.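

In this assay, the aromatic carbon bearing the aryl group proves more sensitive to the choice of aryl group than the first pair alone indicated: the change to 3-(trifluoromethyl)phenyl gives an 8.1-fold higher number from compound 2 to compound 3 (0.91 log units; beyond the scatter), a larger step than a 2.0-fold lower number from compound 1 to compound 2 (0.31 log units; beyond the scatter) and opposite in direction. The same group also compares unfavourably with 2-methylphenyl, with a 4.0-fold higher number from compound 1 to compound 3 (0.60 log units; beyond the scatter), so among these three compounds the 3-(trifluoromethyl)phenyl group gives the highest number and 3,5-dimethylphenyl the lowest. The two groups exchanged between compound 2 and compound 3 match in ring type, hydrogen-bond donor and acceptor counts and net charge, so the large step comes with a change that these counts register only as a difference in heavy atoms and the presence of fluorine.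

Nothing available here accounts for the rise in the number. The compounds shown leave open whether the step follows the trifluoromethyl group itself or the loss of the second methyl group, and a plain phenyl group or a methoxy-bearing phenyl group at the same carbon would help to separate these readings.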